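A longer piperidine side chain at the solubility limit

This account rests on a few compounds, and the source may have more. Where it says the series, first, only, none or still open, it means among the compounds named here.

Measured in a physicochemical assay for solubility, with a stated time of 3 days, at pH 2; a lower number here means a less soluble compound, a higher number a more soluble compound:
Compound 1 `NC(=O)c1ccc2[nH]c(-c3ccc(OCCCO)cc3)nc2c1`: 185000 nM
Compound 2 `CN1CCC(Oc2ccc(-c3nc4cc(C(N)=O)ccc4[nH]3)cc2)C1`: "not determined" (no result reported)
Compound 3 `NC(=O)c1ccc2[nH]c(-c3ccc(OC4CCCNC4)cc3)nc2c1`: > 400000 nM (a limit, not a number)

Compound 3 stands at the limit of > 400000 nM in this assay, at which 1 of the 3 values shown sits, so it offers a limit and no single number. Compound 4 `NC(=O)c1ccc2[nH]c(-c3ccc(OCCCN4CCCCC4)cc3)nc2c1`, not yet measured, carries 3-(piperidin-1-yl)propyl in place of piperidin-3-yl on an oxygen on an aromatic ring. Among the compounds with values here, one measured step bears on this change: an at least 2.1-fold higher number from compound 1 to compound 3 (0.33 log units; beyond the scatter), with piperidin-3-yl in place of 3-hydroxypropyl. On these data alone, that step ends at a limit, so its full size remains open. Compound 4 keeps a six-membered non-aromatic ring with 1 hetero atom, so a large fall back towards compound 1 at 185000 nM is not expected. The expected step is an at least 1.1-fold lower number from compound 3 to compound 4 (0.05 log units; that floor lies within the scatter), which means none beyond the scatter. Compound 4 is estimated at 350000 nM, with an expected range of 170000 nM to 400000 nM.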

Compound 4, solubility: > 400000 nM
Compound 4 was reported as a limit; the forecaster's own chance of this, stated with the estimate: 55%; middle value at least 1.1-fold (0.05 log units) away from the limit.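

Piperidin-1-yl in place of hydroxy on the chain gives an at least 2.1-fold higher number from compound 1 to compound 4 (0.33 log units; beyond the scatter) in this assay, so the higher reading seen with piperidin-3-yl on the oxygen also holds when the ring sits at the end of a propyl chain. Compound 4 gives a limit, not a number, as compound 3 does: the limit of > 400000 nM in this assay, at which 2 of the 4 values shown sit. The step between these two compounds therefore cannot be read, and the two groups cannot be ranked.

On these data alone, it remains open how far either compound lies past the limit. Also open, as far as these compounds go, is whether a shorter chain carrying the same piperidine, or a morpholine in its place, would reach it.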